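The source may hold more compounds than are shown below. What is called first, only, known or untested is meant among the compounds shown, and "the series" means these compounds.

Of the compounds shown here, three built on one shared core have been tested: compound 1 `CCOC(=O)c1cnc(N2CCN(Cc3ccc(F)cc3)CC2)nc1Oc1c(C)cc(-c2ccc(C#N)cc2)cc1C`, compound 2 `CCOC(=O)c1cnc(N2CCN(Cc3ccccc3F)CC2)nc1Oc1c(C)cc(-c2ccc(C#N)cc2)cc1C` and compound 3 `CCOC(=O)c1cnc(N2CCN(Cc3ccc(C(=O)OC)cc3)CC2)nc1Oc1c(C)cc(-c2ccc(C#N)cc2)cc1C`. Each was examined in an ADME assay on MT4 cells (Homo sapiens) for cytotoxicity, read by MTT assay, with a stated time of 4 days; on this read-out lower numbers stand for higher toxicity in this test and higher numbers for lower toxicity in this test. Compound 1 gives > 117000 nM, which is a limit of the test rather than a measured number. Compound 2 likewise gives only a limit, > 125000 nM. Compound 3 also stops at a limit, > 125000 nM, so its standing among the three is simply that it sits at the same ceiling as compound 2 (the limit of > 125000 nM in this assay, at which 2 of the 3 values shown sit), while compound 1 sits at a slightly different ceiling (the limit of > 117000 nM in this assay, at which 1 of the 3 values shown sits).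

Every value here is a limit. The steps between these compounds cannot be sized: a step that the two limits leave unreadable from compound 1 to compound 2, a step that the two limits leave unreadable from compound 1 to compound 3 and a step that the two limits leave unreadable from compound 2 to compound 3 are all unreadable.

Compound 4 `CCOC(=O)c1cnc(N2CCN(Cc3ccc(Br)cc3)CC2)nc1Oc1c(C)cc(-c2ccc(C#N)cc2)cc1C` is not yet measured. Its difference from compound 3 is bromo in place of methoxycarbonyl on an aromatic carbon. Among the compounds with values here, no measured step bears readably on this change, so no shift in this assay beyond the scatter can be expected on the evidence at hand; the estimated step of a number no higher from compound 3 to compound 4 (the limit leaves the size open) is therefore essentially flat. Compound 4 is expected to give about 125000 nM, within a range from 60000 nM to 250000 nM, most likely again reported only as a limit.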

Compound 4, half-maximal cytotoxic concentration: > 125000 nM
Compound 4 ended at the assay's limit; the forecaster's own chance of this, stated with the estimate: 85%; the middle value sits exactly at the limit.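

In this assay compound 4 gives only a limit, so the steps to it from compound 1, compound 2 and compound 3 cannot be read: the limit of > 125000 nM in this assay, at which 3 of the 4 values shown sit.

The compounds shown leave open whether exchanging these groups on the shared core changes the result in this assay at all, for all four values are limits and none is a measured number.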